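Acid chain rearrangement, compound 3 to compound 4

The source may report more compounds than this note shows. Statements on the series, on what has been measured and on what is new or still open speak of the compounds shown alone.

In an ADME assay on the whole organism (strain CD-1) for pharmacokinetics, with Mus musculus as the target, at a dose of 3 mg/kg by the intravenous route (a higher number here means faster removal of the compound, a lower number slower removal), compound 1 `CN(Cc1ccccc1OCCCCC(C)(C)C(=O)O)C(=O)c1ccc(-c2ccco2)cc1` gives 1.3 mL/min/kg and compound 2 `CN(Cc1ccccc1OCCC[C@@H]1C[C@@H]1C(=O)O)C(=O)c1ccc(-c2ccco2)cc1` gives 1.7 mL/min/kg with no separation beyond the scatter (a 1.3-fold higher number from compound 1 to compound 2 (0.12 log units; within the scatter)). Compound 3 `C/C(=C\C(=O)O)CCCOc1ccccc1CN(C)C(=O)c1ccc(-c2ccco2)cc1` is the highest of the three at 11 mL/min/kg and lies beyond the scatter from both others (an 8.5-fold higher number from compound 1 to compound 3 (0.93 log units; beyond the scatter)) and (a 6.5-fold higher number from compound 2 to compound 3 (0.81 log units; beyond the scatter)).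

Compound 4 `C/C(=C\COc1ccccc1CN(C)C(=O)c1ccc(-c2ccco2)cc1)CCC(=O)O` holds the same atoms as compound 3, joined differently (4-carboxy-2-methylbut-1-en-1-yl in place of 4-carboxy-3-methylbut-3-en-1-yl on a saturated chain carbon bound to an oxygen on an aromatic ring): 4-carboxy-2-methylbut-1-en-1-yl in place of 4-carboxy-3-methylbut-3-en-1-yl on a saturated chain carbon bound to an oxygen on an aromatic ring. Among the compounds with values here, no measured step relocates a double bond in this way, so the measured steps bear on this change only indirectly. The largest of them (an 8.5-fold higher number from compound 1 to compound 3 (0.93 log units; beyond the scatter)) shows that a change in this chain can move the number, and it sets the width of the range. The expected step is small (a 1.3-fold higher number from compound 3 to compound 4 (0.10 log units; within the scatter)) and is not expected to exceed the scatter. Compound 4 is estimated at 14 mL/min/kg (expected range 5 mL/min/kg to 35 mL/min/kg).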

Compound 4, clearance: 15 mL/min/kg
For compound 4 the middle estimate is 1.1-fold (0.03 log units) below the measured one; the range from low to high includes it.
By their numbers in this assay, from the lowest: compounds 1 and 2 (each within the scatter of the next); then compounds 3 and 4 (each within the scatter of the next).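

In this assay, replacing 4-carboxy-3-methylbut-3-en-1-yl with 4-carboxy-2-methylbut-1-en-1-yl at this place gives no separation beyond the scatter (a 1.4-fold higher number from compound 3 to compound 4 (0.13 log units; within the scatter)), so this rearrangement of the same atoms does not measurably alter clearance here. Compound 4 also lies beyond the scatter from the chains with no carbon-carbon double bond (an 8.8-fold higher number from compound 2 to compound 4 (0.95 log units; beyond the scatter); a 12-fold higher number from compound 1 to compound 4 (1.06 log units; beyond the scatter)), so among these four compounds, both chains with that double bond give the higher numbers, whichever of the two placements it takes. Nothing available explains this grouping.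

Open, on these data alone, is whether the saturated 4-carboxy-2-methylbutyl chain would fall with compounds 1 and 2 or with compounds 3 and 4 in this assay. Also open, as far as these compounds go, is how a primary amide in place of the carboxylic acid would read there.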